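Phenyl-substituted hydrazides in a whole-animal assay

The compounds below may be only part of what the source reports. "The series", "measured", "known", "first", "only" and "open" are said of these compounds alone.

compound 1 `Cc1ccc(/C=C2/N=C(c3ccccc3)N(C(=O)COc3ccccc3)NC2=O)cc1`: "not active" (no number reported) in a functional assay on the whole organism (strain albino) with Mus musculus as the target, with a stated time of 4 h; a higher number here means that more compound is needed for the effect, a lower number that less compound is needed
compound 2 `Cc1ccc(C(=O)N2NC(=O)/C(=C\c3ccc(O)cc3)N=C2c2ccccc2)cc1`: 300 mg/kg in this assay

Going by the values given here, compound 2 holds the only number in this assay; compound 1 gives no number there. Compound 3 `Cc1ccc(/C=C2/N=C(c3ccccc3)N(C(=O)c3ccc(C)cc3)NC2=O)cc1` differs from compound 2 by methyl in place of hydroxy on an aromatic carbon. Among the compounds with values here, no step between measured compounds is known, so the size of this change cannot be read from the data. The expectation is a step of a 1.3-fold higher number from compound 2 to compound 3 (0.12 log units; within the scatter) that stays near the scatter, with a slight loss of potency as the more likely direction. Compound 3 is therefore estimated at 400 mg/kg, with a range from 180 mg/kg to 900 mg/kg.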

Compound 3, dose for half-maximal effect: 30 mg/kg
Beside the measured number, compound 3's estimate is 13-fold (1.12 log units) above it, and the stated range ends above it.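

In this assay, going by these compounds alone, 4-hydroxyphenyl to 4-methylphenyl gives a 10-fold lower number from compound 2 to compound 3 (1.00 log units; beyond the scatter), the first reading of how much this place matters. A change of one heavy atom on the aromatic carbon para to a large group is enough to move the dose beyond the scatter, so the position is sensitive to its substituent. Nothing at hand accounts for the step.

This rests on a single pair. On these data alone, whether a methoxy group, a chlorine or an amine at this place would behave like methyl or like hydroxy stays open.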